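Working notes on compounds 1 to 4

The compounds below may be only part of what the source reports. "The series", "measured", "known", "first", "only" and "open" are said of these compounds alone.

Measured so far in an ADME assay on HepG2 cells (Homo sapiens) for cytotoxicity, read by CellTiter-Glo and resazurin assay, with a stated time of 72 h; a lower number here means that less compound is needed, a higher number that more compound is needed for the effect:
- Compound 1, `CCOC(=O)CCCCCOc1cccc(CN(C(=O)c2ccc(-c3cccc(-c4ccccc4)c3)cc2)C(C)C)c1`. In this assay compound 1 gives > 26000 nM, which is a limit of the assay.
- Compound 2, `CCOC(=O)CCCCCOc1cccc(CN(C(=O)c2ccc(-c3cccc(O)c3)cc2)C(C)C)c1`. In this assay compound 2 gives > 26000 nM, which is a limit of the assay.
- Compound 3, `CCOC(=O)CCCCCOc1cccc(CN(C(=O)c2ccc(-c3cccc(OC(F)(F)F)c3)cc2)C(C)C)c1`. In this assay compound 3 gives > 26000 nM, which is a limit of the assay.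

Where compound 3 stands: in this assay only a limit is known for compound 3, and the two further values shown are limits as well, all of them being (the limit of > 26000 nM in this assay, at which 3 of the 3 values shown sit). Nothing in these numbers ranks compound 3 against compound 1 or compound 2.

Compound 4 is `CCOC(=O)CCCCCOc1cccc(CN(C(=O)c2ccc(Br)cc2)C(C)C)c1`, not yet measured in this assay. The change from compound 3 is bromo in place of 3-(trifluoromethoxy)phenyl on an aromatic carbon. The two measured steps that bear on it end at the same aromatic carbon: a step that the two limits leave unreadable from compound 1 to compound 3 and a step that the two limits leave unreadable from compound 2 to compound 3. Neither step has a readable size, and the third step, a step that the two limits leave unreadable from compound 1 to compound 2, adds nothing readable either. Among the compounds with values here, there is thus no measured step from which a direction or a size can be drawn for compound 4; the expectation rests only on compound 3 and its two companions all sitting at the limit.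

Compound 4 is expected to stay at that limit, estimated at 30000 nM with a range from 15000 nM to 60000 nM. The expected step is a step that the limit leaves unreadable from compound 3 to compound 4, that is, none beyond the scatter.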

Compound 4, half-maximal effective concentration: > 26000 nM
Compound 4: only a limit was reported; the forecaster's own chance of this, stated with the estimate: 80%; the middle value lies beyond the limit too.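

Within the data shown here, no step from compound 1, compound 2 or compound 3 to compound 4 can be read, since all four compounds sit at the same limit: the limit of > 26000 nM in this assay, at which 4 of the 4 values shown sit. The compounds shown leave open how the four rank against one another, and whether any of these changes on the shared core alters the half-maximal effective concentration.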